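The source may report more compounds than this note shows. Statements on the series, on what has been measured and on what is new or still open speak of the compounds shown alone.

Compound 1, `COc1ccc(-c2cc(/C=C/C(=O)c3ccc(N)cc3)[nH]n2)cc1`, gives 800 nM in a functional assay on MCF7 cells (Homo sapiens) for inhibition, read by MTT assay, with a stated time of 48 h; a higher number here means a weaker inhibitor, a lower number a stronger inhibitor. Compound 3, `COc1ccc(-c2cc(/C=C/C(=O)c3ccc(N)cc3)[nH]n2)cc1OC`, gives 1900 nM in this assay. The two differ in one place, (methoxy in place of hydrogen on an aromatic carbon), and this brings a 2.4-fold higher number from compound 1 to compound 3 (0.38 log units; beyond the scatter). Compound 2, `COc1ccc(C(=O)/C=C/c2cc(-c3cc(OC)c(OC)c(OC)c3)n[nH]2)cc1OC`, gives 510 nM in this assay; the difference between the core of compound 2 and the core of compound 1 is not broken down here. The gap from compound 2 to compound 1 lies within the scatter, while the gap from compound 2 to compound 3 lies beyond it.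

Compound 4, `COc1cc(C(=O)/C=C/c2cc(-c3cc(OC)c(OC)c(OC)c3)n[nH]2)cc(OC)c1OC`, has not yet been measured. It differs from compound 2 by methoxy in place of hydrogen on an aromatic carbon. The surroundings of this place are not identical to those of the earlier pair: here the entering methoxy is also meta to a methoxy group (2 heavy atoms), so this is the same kind of change rather than the same change. A step of a 2.2-fold higher number from compound 2 to compound 4 (0.33 log units; beyond the scatter) is expected; this rests on the earlier step of the same kind, a 2.4-fold higher number from compound 1 to compound 3 (0.38 log units; beyond the scatter), and on compound 2 at 510 nM. Compound 4 is therefore estimated at 1100 nM in this assay, with a range from 450 nM to 2800 nM.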

Compound 4, half-maximal inhibitory concentration: 430 nM
Compound 4: the middle estimate sits 2.6-fold (0.41 log units) above what was measured; the measured number lies below the stated range.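

In this assay, methoxy in place of hydrogen on an aromatic carbon brings a 1.2-fold lower number from compound 2 to compound 4 (0.07 log units; within the scatter), so on this core the change leaves compound 2 and compound 4 indistinguishable. The step seen on the core of compound 1 therefore did not carry over unchanged to the core of compound 2: the same change on two cores in this assay, a 2.4-fold higher number (0.38 log units; beyond the scatter) from compound 1 to compound 3 and a 1.2-fold lower number (0.07 log units; within the scatter) from compound 2 to compound 4, 2.8-fold (0.45 log units) apart, beyond the scatter of two such steps This shows that, in this series, the step measured on one core cannot simply be transferred to the other, but with a single pair on each core it does not show what sets the two steps apart, whether the rest of the core or the surroundings of the entering methoxy, which on compound 4 is ortho to a methoxy group and meta to another.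

On these data alone, what a hydroxy group or an ethoxy group would do at this place remains open on both cores. As far as these compounds go, it also remains open whether the amine of compound 1 and compound 3 has any bearing on the size of the step.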